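The source may report more compounds than this note shows. Statements on the series, on what has been measured and on what is new or still open speak of the compounds shown alone.

Compound 1 `O=C1/C(=C/c2ccc(O)cc2)CCC/C1=C\c1ccc([N+](=O)[O-])cc1` is the starting point of this account, which measures a functional assay on HSG cells (Homo sapiens) for cytotoxicity; on this read-out higher numbers stand for lower toxicity in this test and lower numbers for higher toxicity in this test. In this assay compound 1 gives only a limit, > 400000 nM. Compound 3 `COc1cc(/C=C2/C(=O)/C(=C/c3ccc([N+](=O)[O-])cc3)c3ccccc32)cc(OC)c1OC` likewise gives only a limit in this assay, > 400000 nM. Going by the values given here, compound 2 `O=C1/C(=C/c2ccc(O)cc2)Cc2ccccc2/C1=C\c1ccc([N+](=O)[O-])cc1` is the one member of the set with a full number in this assay, giving 11000 nM. Among the compounds with values here, compound 1 therefore does not stand at a measured number at all but at the limit of > 400000 nM in this assay, at which 2 of the 3 values shown sit, so no step between measured compounds can be read from it.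

Compound 4 `COc1cc(/C=C2\CCC/C(=C\c3ccc([N+](=O)[O-])cc3)C2=O)ccc1O` is not yet measured. It differs from compound 1 by methoxy in place of hydrogen on an aromatic carbon. Within the data shown here, nothing among the measured compounds reports what this particular change does in this assay, so the expectation rests on where compound 1 itself sits. The step from compound 1 to compound 4 is expected to be none beyond the scatter, a number no higher from compound 1 to compound 4 (the limit leaves the size open). In this assay compound 4 is accordingly expected to give about 400000 nM, most likely again reported only as a limit, within a range from 100000 nM to 800000 nM.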

Compound 4, half-maximal cytotoxic concentration: 11000 nM
Beside the measured number, compound 4's estimate is 36-fold (1.56 log units) above it, outside the stated range (below it).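

Going from 4-hydroxyphenyl to 4-hydroxy-3-methoxyphenyl in this assay gives an at least 36-fold lower number from compound 1 to compound 4 (1.56 log units; beyond the scatter), so this aromatic carbon, ortho to the hydroxy group, is a place where a small substituent moves the read-out towards higher toxicity in this test. Going by these compounds alone, none of the earlier compounds showed this, since no step could be read among them, and compound 4 now gives a full number on the core of compound 1. The step remains a minimum, as its starting value is only a limit: the limit of > 400000 nM in this assay, at which 2 of the 4 values shown sit.

The compounds shown leave open whether an ethoxy group, a chlorine atom or an amine at this same place would shift the number as methoxy does. They also leave open whether methoxy would have a comparable effect on the core of compound 2, or without the neighbouring hydroxy group.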